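The source may report more compounds than this note shows. Statements on the series, on what has been measured and on what is new or still open speak of the compounds shown alone.

Measured so far:
compound 1 `N[C@H]1CC[C@H](Oc2ccc([C@H]3CC[C@]4(CC3)OOC3(O4)C4CC5CC(C4)CC3C5)cc2)CC1` — < 7 mL.min-1.g-1
compound 2 `CC(C)(O)CNCCCOc1ccc([C@H]2CC[C@]3(CC2)OOC2(O3)C3CC4CC(C3)CC2C4)cc1` — 8 mL.min-1.g-1
compound 3 `CC(C)(N)CCOc1ccc([C@H]2CC[C@]3(CC2)OOC2(O3)C3CC4CC(C3)CC2C4)cc1` — < 7 mL.min-1.g-1

Going by the values given here, in an ADME assay on microsomes from liver (Homo sapiens) for metabolic stability, read by LC-MS, tested at 1 uM (a lower number here means slower removal, a higher number faster removal of the compound), compound 2 gives 8 mL.min-1.g-1, the only number in the set. Compound 1 gives only a limit there, < 7 mL.min-1.g-1. Compound 3 likewise gives only a limit, < 7 mL.min-1.g-1. Two of the three values sit at that limit (the limit of < 7 mL.min-1.g-1 in this assay, at which 2 of the 3 values shown sit), so compound 2 is read against a floor rather than against firm numbers.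

The next compound, compound 4 `c1cc([C@H]2CC[C@]3(CC2)OOC2(O3)C3CC4CC(C3)CC2C4)ccc1OCC1CCNCC1`, differs from compound 2 as follows: piperidin-4-yl in place of 2-((2-hydroxy-2-methylpropyl)amino)ethyl on a saturated chain carbon bound to an oxygen on an aromatic ring.

Among the compounds with values here, the steps that bear on it are those exchanging the chain on the aromatic oxygen: an at least 1.1-fold higher number from compound 1 to compound 2 (0.05 log units; that floor lies within the scatter) and an at least 1.1-fold lower number from compound 2 to compound 3 (0.05 log units; that floor lies within the scatter), while a step that the two limits leave unreadable from compound 1 to compound 3. None of these shifts is readable as beyond the scatter, and compound 2 itself sits close to the floor. The expectation for compound 4 in this assay is therefore only a small move, a 1.1-fold lower number from compound 2 to compound 4 (0.06 log units; within the scatter), toward the floor. The estimate for compound 4 is 7 mL.min-1.g-1, range 4 mL.min-1.g-1 to 14 mL.min-1.g-1, with a fair chance that only a limit is returned.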

Compound 4, intrinsic clearance in microsomes: < 7 mL.min-1.g-1
Compound 4 ended at the assay's limit (the forecaster's own chance of this, stated with the estimate: 50%); the middle value sits exactly at the limit.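

In this assay the exchange of the open chain for piperidin-4-yl reads as an at least 1.1-fold lower number from compound 2 to compound 4 (0.05 log units; that floor lies within the scatter), so placing the amine in a six-membered non-aromatic ring on this saturated chain carbon shows no readable shift. Compound 4 gives only a limit, < 7 mL.min-1.g-1, and its steps from compound 1 and compound 3 cannot be read. With this result, the floor now holds most of the series: the limit of < 7 mL.min-1.g-1 in this assay, at which 3 of the 4 values shown sit.

Going by these compounds alone, compound 2 remains the only number in the set, so it stays open how far any change at this position can move the read-out. From the compounds shown here alone, what a longer chain carrying piperidin-4-yl, or a carboxylic acid in its place, would give in this assay also stays open.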